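A few compounds are considered here, and "the series" means these few. Any claim that something is new, unique, unknown or untested is made for them only; others in the source may bear on it.

Compound 2 `Cc1nn(-c2ccccc2)cc1/C=N/Nc1nc(Nc2ccccc2)nc(Nc2ccc(S(N)(=O)=O)cc2)n1` was examined in a functional assay on KM12 cells (Homo sapiens) for inhibition, read by sulforhodamine B assay, with a stated time of 48 h; on this read-out higher numbers stand for lower toxicity in this test and lower numbers for higher toxicity in this test. In this assay compound 2 gives > 100000 nM, which is a limit of the assay and not a number; it sits at the limit of > 100000 nM in this assay, at which 1 of the 2 values shown sits. The related compound 1 `NS(=O)(=O)c1ccc(Nc2nc(N/N=C/c3ccc(C(F)(F)F)cc3)nc(Nc3ccccc3)n2)cc1` gives 24800 nM in this assay. Going by the values given here, the one measured step, an at least 4.0-fold higher number from compound 1 to compound 2 (0.60 log units; beyond the scatter), is the only guide to how the group on the carbon with a double bond to nitrogen moves the read-out. Compound 3 `NS(=O)(=O)c1ccc(Nc2nc(N/N=C/c3ccccn3)nc(Nc3ccccc3)n2)cc1` differs from compound 2 by pyridin-2-yl in place of 3-methyl-1-phenyl-1H-pyrazol-4-yl on a carbon with a double bond to nitrogen. Among the compounds with values here, the entering group is smaller than the group it replaces and closer in size to the group of compound 1, so the step is expected to run back in the direction of higher toxicity, though with the single step as the only evidence its size is uncertain. Compound 3 is therefore expected to show a step of an at least 2.0-fold lower number from compound 2 to compound 3 (0.30 log units; that floor lies within the scatter), giving an estimated 50000 nM in this assay, with a range from 15000 nM to 150000 nM.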

Compound 3, concentration lethal to 50% of the cells: > 100000 nM
Compound 3: no number, only a limit; the forecaster's own chance of this, stated with the estimate: 40%; at least 2.0-fold (0.30 log units) between middle value and limit.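

Compound 3 also ends at a limit of the assay and not a number, so the step that joins it to compound 2 cannot be read, and two different groups on the carbon with a double bond to nitrogen now sit at the same limit: the limit of > 100000 nM in this assay, at which 2 of the 3 values shown sit. The readable step is an at least 4.0-fold higher number from compound 1 to compound 3 (0.60 log units; beyond the scatter), which is beyond the scatter. Pyridin-2-yl in place of 3-methyl-1-phenyl-1H-pyrazol-4-yl therefore did not bring the read-out in this assay back to that of compound 1.

Going by these compounds, how far compound 2 and compound 3 lie past the limit stays open. Also open, on these data alone, is whether the value of compound 1 goes with its trifluoromethyl group, which a plain phenyl or a 4-chlorophenyl on that carbon would help to settle.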